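A Larger Ring on the Nitrogen

The compounds below may be only part of what the source reports. "The series", "measured", "known", "first", "only" and "open" are said of these compounds alone.

In an ADME assay on microsomes from liver (Mus musculus) for metabolic stability, read by LC-MS, using NADPH, with a stated time of 10 min, tested at 10 uM (on this read-out higher numbers stand for a longer-lived compound and lower numbers for a shorter-lived compound), compound 1 `N#Cc1ccnc(Oc2nn(C3CCC3)c3ncnc(N)c23)c1` gives 0.4 h. Compound 2 `Nc1ncnc2c1c(Oc1cc(C(F)(F)F)ccn1)nn2C1CC1` gives > 2.41 h, which is a limit of the assay and not a number. This places compound 2 at the limit of > 2.41 h in this assay, at which 1 of the 2 values shown sits. Its true half-life is therefore not known.

Compound 3 `Nc1ncnc2c1c(Oc1cc(C(F)(F)F)ccn1)nn2[C@H]1CC[C@H](CO)CC1` keeps the rest of compound 2 but carries 4-(hydroxymethyl)cyclohexyl in place of cyclopropyl on an aromatic nitrogen. Among the compounds with values here, no measured pair of compounds here differs in one place only, so the expectation rests on this structural change alone. A shorter half-life in this assay is expected, by a step modestly beyond the usual scatter. The estimated change is an at least 2.4-fold lower number from compound 2 to compound 3 (0.38 log units; beyond the scatter). For compound 3 the expected half-life is 1 h, within an estimated range of 0.3 h to 2.8 h.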

Compound 3, half-life: 0.383 h
Beside the measured number, compound 3's estimate is 2.6-fold (0.42 log units) above it; the measured number falls inside the stated range.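

Within the data shown here, this is the first comparison here in which the two compounds differ only in the group on the aromatic nitrogen, and in this assay, 4-(hydroxymethyl)cyclohexyl in place of cyclopropyl gives an at least 6.2-fold lower number from compound 2 to compound 3 (0.79 log units; beyond the scatter). The half-life therefore depends on what this position carries, by a step beyond the usual scatter. The value of compound 2 is a limit of the assay and not a number, so the true size of the step stays unknown: the limit of > 2.41 h in this assay, at which 1 of the 3 values shown sits.

The change brings a larger ring and a hydroxymethyl group together, so the compounds shown cannot tell which of the two goes with the shorter half-life. A plain cyclohexyl would separate the two, and an amine or a carboxylic acid in place of the hydroxymethyl would show how much the ring's substituent matters.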